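This account rests on a few compounds, and the source may have more. Where it says the series, first, only, none or still open, it means among the compounds named here.

Measured so far:
compound 1 `COc1cc(-c2cc(/C=C/C(=O)c3ccc(N)cc3)[nH]n2)cc(OC)c1OC` — -95%
compound 2 `COc1ccc(C(=O)/C=C/c2cc(-c3cc(OC)c(OC)c(OC)c3)n[nH]2)cc1` — -89%

The read-out is a functional assay on SK-MEL-5 cells (Homo sapiens) for cytotoxicity, read by sulforhodamine B assay, with a stated time of 48 h, tested at 10 uM; a higher number here means a weaker effect of the compound at the concentration tested, a lower number a stronger effect. In this assay, for the measured compounds named here, compound 1 gives the lowest of the two numbers; its only neighbour is compound 2, which lies a number 6 percentage points higher from compound 1 to compound 2 (within the scatter). That single measured step, methoxy in place of amino on an aromatic carbon, does not separate the two compounds.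

Compound 3 `COc1cc(-c2cc(/C=C/C(=O)c3ccc(F)c(F)c3)[nH]n2)cc(OC)c1OC` differs from compound 1 by 3,4-difluorophenyl in place of 4-aminophenyl on a carbonyl carbon. Going by the values given here, no measured step covers this exchange; the step from compound 1 to compound 2 altered one group on the same ring and stayed within the scatter, so it offers no firm guide to a difluorophenyl replacement. For compound 3 the expectation is a weaker effect in this assay, a step of a number 25 percentage points higher from compound 1 to compound 3 (beyond the scatter), with wide uncertainty. The estimate for compound 3 in this assay is -70%, spanning -100% to -10%.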

Compound 3, a percentage reported as activity, at one concentration (the size of the read-out at that concentration, not a potency): -21%
Compound 3: middle estimate off by 49 percentage points, on the low side, and the stated range covers the measured number.
By their numbers in this assay, from the lowest: compounds 1 and 2 (each within the scatter of the next); then compound 3.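

In this assay, the group on the carbonyl carbon turns out to matter greatly: 3,4-difluorophenyl in place of 4-aminophenyl gives a number 74 percentage points higher from compound 1 to compound 3 (beyond the scatter), and 3,4-difluorophenyl in place of 4-methoxyphenyl gives a number 68 percentage points higher from compound 2 to compound 3 (beyond the scatter). The exchange of amino for methoxy on this ring had not separated compound 1 from compound 2, so that pair alone gave no sign that this position could carry so large a change. Nothing available accounts for the size of these steps.

Open, going by these compounds, is whether the change follows from the fluorines themselves or from the loss of a group such as amino or methoxy on the ring. Plain phenyl, 4-fluorophenyl and 4-hydroxyphenyl on the same carbonyl carbon would bear on that question.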